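A few compounds are considered here, and "the series" means these few. Any claim that something is new, unique, unknown or untested is made for them only; others in the source may bear on it.

Measured compounds in a functional assay on CHO cells for antagonist activity at Orexin/Hypocretin receptor type 1 (Homo sapiens), read by FLIPR and calcium flux; on this read-out lower numbers stand for lower potency and higher numbers for higher potency (the scale is a negative logarithm):

Compound 1, `Cc1ccc(-c2ncccn2)c(C(=O)N2CC3(CC3)C[C@H]2CNc2ccc(C(F)(F)F)cn2)n1`, gives 8.4.
Compound 2, `Cc1ccc(-c2ncccn2)c(C(=O)N2CC3(CC3)C[C@H]2CNc2cc(C(F)(F)F)ccn2)c1`, gives 7.3.
Compound 3, `Cc1ccc(-c2ncccn2)c(C(=O)N2CC3(CC3)C[C@H]2CNc2ccc(C(F)(F)F)cn2)c1`, gives 8.7.

Compounds 1 and 3 share the same amide and spirocyclic amine portion and the same 5-(trifluoromethyl)pyridin-2-yl group on the amine nitrogen; how their two cores differ is not broken down here. Their values in this assay lie within the usual scatter of each other, so no order between them is claimed. Compound 2 sits clearly lower than both.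

Going by the values given here, the one counted change in the set is 4-(trifluoromethyl)pyridin-2-yl in place of 5-(trifluoromethyl)pyridin-2-yl on an amine nitrogen. This step is a number 1.40 log units lower from compound 3 to compound 2 (beyond the scatter), the only large effect seen among the three measured compounds.

Compound 4, `Cc1ccc(-c2ncccn2)c(C(=O)N2CC3(CC3)C[C@H]2CNc2cc(C(F)(F)F)ccn2)n1`, is not yet measured. It differs from compound 1 by 4-(trifluoromethyl)pyridin-2-yl in place of 5-(trifluoromethyl)pyridin-2-yl on an amine nitrogen, at the same place as the change from compound 3 to compound 2: in both cases the amine nitrogen carries a saturated chain carbon as its other neighbour. It is therefore treated as the same change, made on the core of compound 1 instead of the core of compound 3.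

Given only one measured instance, the expectation for compound 4 rests on that single step. Among the compounds with values here, the estimated step in this assay is a number 1.40 log units lower from compound 1 to compound 4 (beyond the scatter), taken to match the step from compound 3 to compound 2 because a number 1.40 log units lower from compound 3 to compound 2 (beyond the scatter) is the only guide available, with the starting point set by compound 1 at 8.4. From the compounds shown here alone, compound 4 is accordingly expected to give about 7, with a plausible range from 6.4 to 7.6, the width reflecting that the transfer of a step between two different cores is untested here.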

Compound 4, negative logarithm of the antagonist equilibrium constant: 6
Compound 4: middle estimate off by 1.00 log units, on the high side; measured number below the stated range.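

In this assay, moving from 5-(trifluoromethyl)pyridin-2-yl to 4-(trifluoromethyl)pyridin-2-yl on the amine nitrogen lowers the number again, now with a number 2.40 log units lower from compound 1 to compound 4 (beyond the scatter). The direction of the change carries from one core to the other, but its size does not: the same change on two cores in this assay, a number 1.40 log units lower (beyond the scatter) from compound 3 to compound 2 and a number 2.40 log units lower (beyond the scatter) from compound 1 to compound 4, 1.00 log units apart, beyond the scatter of two such steps. This shows that, in this series, a step measured on one core is a guide to sign and not to size; with only two instances, it does not show why the size differs, nor does it give a rule for how the change would behave on a third core.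

The compounds shown leave open whether the size of a change at this place depends on the core for other groups as well, for example a nitrile or a methoxy group in place of the trifluoromethyl on the pyridine ring. Also open, from the compounds shown here alone, is whether the larger step on the core of compound 1 belongs to the trifluoromethyl group itself, or would appear with any group moved in the same way.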